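Methylamino to amino on the shared core

This account rests on a few compounds, and the source may have more. Where it says the series, first, only, none or still open, it means among the compounds named here.

In a functional assay on SW480 cells (Homo sapiens) for antiproliferative activity, read by MTT assay, with a stated time of 48 h (on this read-out higher numbers stand for weaker inhibition and lower numbers for stronger inhibition), compound 1 `CCCCCCCCC(CCO)n1cnc2c(Cl)ncnc21` gives 1370 nM. Compound 2 `CCCCCCCCC(CCO)n1cnc2c(NC)ncnc21` gives 3770 nM, the highest of the two numbers and so the weaker inhibition of the pair.

Compound 3 `CCCCCCCCC(CCO)n1cnc2c(N)ncnc21` has not yet been measured. Its difference from compound 2 is hydrogen in place of methyl on a nitrogen on an aromatic ring, or methylamino to amino.

Among the compounds with values here, only one measured step bears on this change, and only indirectly. That step is a 2.8-fold higher number from compound 1 to compound 2 (0.44 log units; beyond the scatter), with methylamino in place of chloro on an aromatic carbon. It is modest but beyond the scatter. Within the data shown here, no measured pair shows the loss of a methyl from this nitrogen, so the data give no firm direction in this assay. A shift smaller than that modest step is expected, most likely within the scatter, with only a slight lean towards lower numbers.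

The expected step is a 1.3-fold lower number from compound 2 to compound 3 (0.10 log units; within the scatter). For compound 3 the estimate is 3000 nM, with an expected range of 1200 nM to 7500 nM.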

Compound 3, half-maximal inhibitory concentration: 20700 nM
For compound 3 the middle estimate is 6.9-fold (0.84 log units) below the measured one; measured number above the stated range.
By their numbers in this assay, from the lowest: compound 1; then compound 2; then compound 3.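

In this assay, the loss of the methyl from this nitrogen is a real change rather than a silent one: the read-out gives a 5.5-fold higher number from compound 2 to compound 3 (0.74 log units; beyond the scatter) and so moves further in the direction already seen with a 2.8-fold higher number from compound 1 to compound 2 (0.44 log units; beyond the scatter) on this aromatic carbon. Measured directly against the chloro group, the amino group gives a 15-fold higher number from compound 1 to compound 3 (1.18 log units; beyond the scatter), so the three groups at this place now rank chloro, methylamino, amino from lowest to highest number, with every step beyond the scatter and no compound shown going against that order. Nothing at hand accounts for this order, and no supporting measurement bears on it.

Going by these compounds, it remains open whether a larger group on this nitrogen, such as ethyl, or a second methyl as in dimethylamino, would continue the rise or reverse it, and whether bromo or methoxy on the same aromatic carbon would fall near chloro. Also open, on these data alone, is whether the same order holds on the shared core with a shorter chain or with a carboxylic acid in place of the hydroxyl.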